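A few compounds are considered here, and "the series" means these few. Any claim that something is new, unique, unknown or untested is made for them only; others in the source may bear on it.

Measured compounds in a toxicity assay on HepG2 2.2.15 cells (Homo sapiens) for cytotoxicity, read by CellTiter-Glo; on this read-out higher numbers stand for lower toxicity in this test and lower numbers for higher toxicity in this test:

Compound 1, `O=C1NC(c2ccccc2)CN1c1cnn2c1CN(C(=O)Nc1cc(F)c(F)c(F)c1)C(C1CC1)C2`: 38500 nM
Compound 3, `C[C@H]1Cn2ncc(N3CC(c4ccccc4)CC3=O)c2CN1C(=O)Nc1cc(F)c(F)c(F)c1`: 12800 nM
Compound 2, `C[C@H]1Cn2ncc(N3CC(c4ccccc4)CC3=O)c2CN1C(=S)Nc1cc(F)c(F)c(F)c1`: > 2000 nM, a limit only

Of the two numbers in hand, compound 1 stands highest in this assay. Its nearest neighbour, compound 3, gives 12800 nM, a gap beyond the scatter. For compound 2 this assay reports only a limit, (the limit of > 2000 nM in this assay, at which 1 of the 3 values shown sits), and not a number.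

Compound 4, `O=C1CC(c2nccs2)CN1c1cnn2c1CN(C(=O)Nc1cc(F)c(F)c(F)c1)C(C1CC1)C2`, has not yet been measured. It differs from compound 1 in one place: 2-oxo-4-(1,3-thiazol-2-yl)pyrrolidin-1-yl in place of 2-oxo-4-phenylimidazolidin-1-yl on an aromatic carbon. Going by the values given here, no pair of measured compounds shows this particular change, so no measured step guides the expectation. He would expect the step in this assay from compound 1 to compound 4 to be small, if anything a little downward, and most likely not beyond the scatter. On that basis compound 4 is estimated at 30000 nM, with a range from 10000 nM to 90000 nM, which corresponds to an expected step of a 1.3-fold lower number from compound 1 to compound 4 (0.11 log units; within the scatter).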

Compound 4, half-maximal cytotoxic concentration: 115000 nM
Estimate against measurement, compound 4: 3.8-fold (0.58 log units) below; the whole stated range lies below it.
By their numbers in this assay, from the lowest: compound 3; then compound 1; then compound 4.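

In this assay, putting 2-oxo-4-(1,3-thiazol-2-yl)pyrrolidin-1-yl in place of 2-oxo-4-phenylimidazolidin-1-yl on an aromatic carbon of the five-membered aromatic ring with 2 nitrogen gives a 3.0-fold higher number from compound 1 to compound 4 (0.48 log units; beyond the scatter), a modest step towards lower toxicity in this test. Going by these compounds alone, this is the first step between compounds differing in one place, and it shows that the group at this position can shift the reading on an otherwise unchanged core. Nothing measured here explains the step.

The change alters the non-aromatic ring and its aromatic substituent together, so the contribution of each remains unseparated. As far as these compounds go, how a pyridin-2-yl group on the same ring, or a simple amine in place of the whole group, would read in this assay also remains open.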